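The source may report more compounds than this note shows. Statements on the series, on what has been measured and on what is new or still open speak of the compounds shown alone.

Working notes on the series. Compound 1 `Clc1ccccc1-c1ccn2ncnc2n1` is one of two measured members. In a functional assay on MDA-MB-231 cells (Homo sapiens) for inhibition, read by resazurin assay, with a stated time of 72 h (on this read-out higher numbers stand for weaker inhibition and lower numbers for stronger inhibition), compound 1 gives only a limit, > 100000 nM. The other measured member, compound 2 `COc1ccc(F)cc1-c1ccn2ncnc2n1`, in this assay likewise gives only a limit, > 100000 nM. Where compound 1 stands can therefore be stated only this far: it sits at the limit of > 100000 nM in this assay, at which 2 of the 2 values shown sit, together with the one other value shown. For the measured compounds named here, no step between measured compounds can be computed. Compound 3 `Clc1ccccc1-c1ccccc1-c1ccn2ncnc2n1` is not yet measured; it differs from compound 1 by 2-chlorophenyl in place of chloro on an aromatic carbon. The measured compounds give no direction for this change, and no step beyond the scatter is expected; the result may once more be a limit. For compound 3 in this assay a value of about 80000 nM is estimated, within 15000 nM to 300000 nM. The step that this estimate means, an at least 1.2-fold lower number from compound 1 to compound 3 (0.09 log units; that floor lies within the scatter), is expected to be small.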

Compound 3, half-maximal inhibitory concentration: > 100000 nM
Compound 3 was reported as a limit (the forecaster's own chance of this, stated with the estimate: 70%); middle value at least 1.2-fold (0.09 log units) from the limit.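

In this assay compound 3 gives > 100000 nM as a limit of the assay, so no new step can be read from compound 1 to compound 3. The compounds shown leave open whether 2-chlorophenyl in place of chloro on an aromatic carbon changes inhibition at all, and in which direction.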